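From a Single Hydrogen to a Hydroxypropyl Arm

The source may hold more compounds than are shown below. What is called first, only, known or untested is meant among the compounds shown, and "the series" means these compounds.

Compound 1 `CCCCCCCCc1ccc(CCC(N)CO)cc1`: > 10 mg/kg, a limit of the assay rather than a number.
Compound 2 `CCCCCCCOc1ccc(CCC(N)(CC)CO)cc1`: 0.044 mg/kg.

The measure throughout is a functional assay on the whole organism (spleen, spleen) with Rattus norvegicus as the target; on this read-out lower numbers stand for an effect already at smaller amounts and higher numbers for an effect only at larger amounts of compound. In this assay compound 1 gives > 10 mg/kg, which is a limit of the assay and not a measured number. Compound 1 therefore stands at the limit of > 10 mg/kg in this assay, at which 1 of the 2 values shown sits, and nothing more can be said of where it lies beyond that. Among the measured compounds shown here, compound 2 gives 0.044 mg/kg in this assay; compound 2 differs from compound 1 in more than one place, so the two values show only that compound 2 was measured with a number and compound 1 was not.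

Compound 3 `CCCCCCCCc1ccc(CCC(N)(CO)CCCO)cc1` is the unmeasured analogue of compound 1. The change is 3-hydroxypropyl in place of hydrogen on a saturated chain carbon bound to an amine nitrogen and two saturated chain carbons. For the measured compounds named here, no measured step of this kind is available, so the size of the step can only be estimated from what the two measured compounds show. For compound 3 the expected step of an at least 33-fold lower number from compound 1 to compound 3 (1.52 log units; beyond the scatter) is a gain in this assay beyond the usual scatter. Compound 3 is estimated at 0.3 mg/kg, within a range from 0.03 mg/kg to 3 mg/kg.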

Compound 3, dose for 50% inhibition: 0.021 mg/kg
The estimate for compound 3 lay 14-fold (1.15 log units) above the measured number, and the stated range ends above it.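

In this assay, among the compounds shown here, 3-hydroxypropyl in place of hydrogen on a saturated chain carbon bound to an amine nitrogen and two saturated chain carbons gives an at least 470-fold lower number from compound 1 to compound 3 (2.67 log units; beyond the scatter), the first step in this account that can be tied to a single place, since compound 1 and compound 2 differ in more than one. Compound 1 stands at > 10 mg/kg, which is a limit of the assay and not a number. The step therefore sets only a floor on the size of this change and leaves its full size unknown, because compound 1 rests on a limit: the limit of > 10 mg/kg in this assay, at which 1 of the 3 values shown sits.

Going by these compounds, whether the gain depends on the hydroxyl at the end of the arm or on the carbon chain alone remains open, and a plain propyl, a methyl or a 2-hydroxyethyl on the same carbon would be needed to separate the two. Compound 2 differs from compound 3 in more than one place, so its value does not settle this question.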